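This account rests on a few compounds, and the source may have more. Where it says the series, first, only, none or still open, it means among the compounds named here.

Working notes on the series, all values from a functional assay on U-373MG ATCC cells for inhibition, with U373 MG (Homo sapiens) as the target, read by MTT assay, with a stated time of 72 h; a higher number here means a weaker inhibitor of growth, a lower number a stronger inhibitor of growth. In this assay compound 1 (`CC(C)=CC(=O)NC(=N)N`) gives > 100000 nM as its reading, which is a limit of the assay and not a number. Going by the values given here, compound 2 (`CC(C)=CCC/C(C)=C/C(=O)NC(=N)NC(=O)C=C(C)C`) gives 36200 nM as its reading, the only true number so far.

Compound 3 (`CC(C)=CCC/C(C)=C/C(=O)NC(=N)N`) has not yet been measured. The change from compound 2 is hydrogen in place of (2-methylprop-1-en-1-yl)carbonyl on an amine nitrogen and it leaves hydrogen on that amine nitrogen, as in compound 1. Among the compounds with values here, no measured step isolates this change, so its size in this assay has to be judged. A modest weakening of growth inhibition is expected, meaning a somewhat higher number, and a result within the usual scatter would not surprise. This expectation starts from compound 2 at 36200 nM as its anchor. It also takes into account that compound 1, with hydrogen at that place, ended at a limit. The estimated move is a 1.5-fold higher number from compound 2 to compound 3 (0.18 log units; within the scatter) in this direction. For compound 3 the estimated value is 55000 nM with an expected range of 25000 nM to 90000 nM for the coming measurement.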

Compound 3, concentration for 50% growth inhibition: 46000 nM
For compound 3 the middle estimate is 1.2-fold (0.08 log units) above the measured one, and the stated range covers the measured number.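

In this assay, hydrogen in place of (2-methylprop-1-en-1-yl)carbonyl on this amine nitrogen gives a 1.3-fold higher number from compound 2 to compound 3 (0.10 log units; within the scatter), so compound 2 and compound 3 cannot be told apart, and this acyl group makes no readable difference to growth inhibition in the pair. The reading of compound 1 is a limit of the assay and not a number: the limit of > 100000 nM in this assay, at which 1 of the 3 values shown sits. Even so, with hydrogen on the amine nitrogen in both compounds, 3-methylbut-2-en-1-yl in place of hydrogen on a saturated chain carbon bound to a double-bonded chain carbon gives an at least 2.1-fold lower number from compound 1 to compound 3 (0.33 log units; beyond the scatter), which makes the chain change, and not the acyl change, the one step here beyond the scatter, with its full size left unfixed by the limit.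

The compounds shown leave open whether a different acyl group on the same amine nitrogen, such as acetyl or benzoyl, would also leave the reading in this assay unchanged. They also leave open how far the chain effect extends, for example whether a longer chain, or a chain ending in an amine or a carboxylic acid, would shift the reading further.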